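Hydroxyquinoline carboxanilides: lipophilicity on replacing the para halogen

This account rests on a few compounds, and the source may have more. Where it says the series, first, only, none or still open, it means among the compounds named here.

Compound 2 `O=C(Nc1ccc(Br)cc1)c1ccc2cccc(O)c2n1` is the bromo analogue of compound 1 `O=C(Nc1ccc(Cl)cc1)c1ccc2cccc(O)c2n1`. Among the measured compounds shown here, in a physicochemical assay for lipophilicity, read by HPLC (a lower number here means a more polar compound, a higher number a more lipophilic compound), compound 1 gives 2.5 and compound 2 gives 2.5; the only measured step, no change at the digits printed from compound 1 to compound 2 (within the scatter), is flat, so compound 2 sits level with compound 1. Compound 3 `O=C(Nc1ccc([N+](=O)[O-])cc1)c1ccc2cccc(O)c2n1` is reached by the change (nitro in place of bromo on an aromatic carbon), the new group standing on an aromatic carbon of the carbon-only six-membered ring, para to a large group. For the measured compounds named here, no measured step carries a halogen to a nitro group, so the halogen swap from compound 1 to compound 2 does not bear on it; the step can only be judged from the groups themselves. Since a nitro group brings two hydrogen-bond acceptors where bromine brought none, compound 3 is expected to read lower than compound 2 in this assay, by a number 0.80 log units lower from compound 2 to compound 3 (beyond the scatter), a step beyond the scatter. For compound 3 the estimate is 1.7, within 1.2 to 2.2.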

Compound 3, partition coefficient: 2.5
The estimate for compound 3 lay 0.80 log units below the measured number; the measured number lies above the stated range.
By their numbers in this assay, from the lowest: compounds 1, 2 and 3 (each within the scatter of the next).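

At the aromatic carbon para to a large group, this assay shows no change at the digits printed from compound 2 to compound 3 (within the scatter) and no change at the digits printed from compound 1 to compound 3 (within the scatter) when nitro takes the place of a halogen. The flat reading at this position therefore extends beyond a swap of one halogen for another: nitro brings 3 heavy atoms and 2 hydrogen-bond acceptors where bromo has 1 heavy atom and 0 hydrogen-bond acceptors, yet compounds 1, 2 and 3 remain within the scatter of each other. Nothing available explains why these readings stay level.

From the compounds shown here alone, whether this level reading would persist with an amine, a carboxylic acid or a longer alkyl chain at the same position remains open. Also open, going by these compounds, is whether the same swaps elsewhere on the shared core would read level in this assay.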